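A few compounds are considered here, and "the series" means these few. Any claim that something is new, unique, unknown or untested is made for them only; others in the source may bear on it.

Compound 1, `Cn1c(CN2CCN(c3nc(Cl)ccc3C(F)(F)F)CC2)nc2cc(C(F)(F)F)ccc21`, compound 2, `Cn1c(CN2CCN(c3nc(Cl)ccc3C(F)(F)F)CC2)nc2cc(F)ccc21`, and compound 3, `Cn1c(CN2CCN(c3ccccc3F)CC2)nc2ccccc21`, have been tested in an assay on CHO cells with metabotropic glutamate receptor 2 (Homo sapiens) as the target, read by FLIPR; a lower number here means that less compound is needed, a higher number that more compound is needed for the effect. Compound 1 gives 2000 nM, compound 2 gives 200 nM and compound 3 gives 794 nM. Compound 2 and compound 1 differ in one place only, (trifluoromethyl in place of fluoro on an aromatic carbon), on an aromatic carbon of a six-membered aromatic ring of carbon only, part of a fused or bridged system of two rings, meta to a fused ring and para to a fused ring; this single change produced a 10-fold higher number from compound 2 to compound 1 (1.00 log units; beyond the scatter). Compound 3 sits beyond the scatter from both of the others, higher than compound 2 and lower than compound 1. The difference between the core of compound 3 and the core of compound 2 is not broken down here.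

Compound 4, `Cn1c(CN2CCN(c3ccccc3C(F)(F)F)CC2)nc2ccccc21`, has not yet been measured. It differs from compound 3 by trifluoromethyl in place of fluoro on an aromatic carbon, here on an aromatic carbon of a six-membered aromatic ring of carbon only, ortho to a large group. The surroundings of the place are therefore not those of the earlier pair, so this is the same kind of change rather than the same change. A higher number is nevertheless expected for compound 4 because a 10-fold higher number from compound 2 to compound 1 (1.00 log units; beyond the scatter), with the size left uncertain by the different place. The expected step is a 3.1-fold higher number from compound 3 to compound 4 (0.50 log units; beyond the scatter). In this assay compound 4 is estimated at 2500 nM, between 800 nM and 8000 nM.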

Compound 4, half-maximal effective concentration: 316 nM
Estimate against measurement, compound 4: 7.9-fold (0.90 log units) above; measured number outside the range, below it.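

In this assay trifluoromethyl in place of fluoro gave a 2.5-fold lower number from compound 3 to compound 4 (0.40 log units; beyond the scatter) and so moved the number in the opposite direction to the earlier pair. The change therefore does not carry from one core to another in this series as a fixed step, in either direction or size: the same change on two cores in this assay, a 10-fold higher number (1.00 log units; beyond the scatter) from compound 2 to compound 1 and a 2.5-fold lower number (0.40 log units; beyond the scatter) from compound 3 to compound 4, 25-fold (1.40 log units) apart, beyond the scatter of two such steps. This does not show why the two steps differ, since the pairs differ both in the place of the change, ortho to a large group in the new pair, and in the rest of the core, and these two differences cannot be separated here; two pairs also give no rule for what the change would do on a third core.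

From the compounds shown here alone, it remains open whether the reversal follows the place of the change or the other groups on the core, and a pair with the change at the same place on a different core would be needed to decide this. Among the compounds shown, only fluoro and trifluoromethyl are compared at this place, so it is also open how a nitrile, a methoxy group or an amine there would compare with them on either core.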